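Trimethoxystyryl thienopyrimidines: the amine substituent

A few compounds are considered here, and "the series" means these few. Any claim that something is new, unique, unknown or untested is made for them only; others in the source may bear on it.

Compound 1 `COc1cc(/C=C/c2nc(N(C)C)c3sccc3n2)cc(OC)c1OC`: in a functional assay on L02 cells (Homo sapiens) for inhibition, read by Griess assay, with stated times of 1 h and 24 h (a lower number here means a stronger inhibitor, a higher number a weaker inhibitor), compound 1 gives > 1000000 nM, a limit of the assay and not a number.
Compound 2 `CCN1CCN(c2nc(/C=C/c3cc(OC)c(OC)c(OC)c3)nc3ccsc23)CC1`: in this assay compound 2 gives > 1000000 nM, again a limit.
Compound 3 `COc1cc(/C=C/c2nc(Nc3ccc(O)cc3)c3sccc3n2)cc(OC)c1OC`: in this assay compound 3 gives > 1000000 nM, also a limit.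

All three measured compounds share the core of compound 1 and differ only in the amine on the aromatic carbon. Every measured step is unreadable: a step that the two limits leave unreadable from compound 1 to compound 2, a step that the two limits leave unreadable from compound 1 to compound 3 and a step that the two limits leave unreadable from compound 2 to compound 3. The reason is plain, because the limit of > 1000000 nM in this assay, at which 3 of the 3 values shown sit, leaves no step that can be read; compound 3 therefore stands at the limit, with no number of its own.

Compound 4 `COc1cc(/C=C/c2nc(NCc3ccccc3Cl)c3sccc3n2)cc(OC)c1OC` carries the next change on the same nitrogen: 2-chlorobenzyl in place of 4-hydroxyphenyl on a nitrogen on an aromatic ring. Among the compounds with values here, the steps that bear on it, from compound 1 to compound 2, from compound 1 to compound 3 and from compound 2 to compound 3, each carry no readable size, so no direction beyond the scatter can be expected for the step from compound 3 to compound 4, a number no higher from compound 3 to compound 4 (the limit leaves the size open).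

Compound 4 is accordingly expected at 1000000 nM, in the range 100000 nM to 3000000 nM, most likely reported again as a limit only.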

Compound 4, half-maximal inhibitory concentration: > 1000000 nM
Compound 4 gave a limit, no number; the forecaster's own chance of this, stated with the estimate: 75%; the middle value sits exactly at the limit.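

No step from compound 1, compound 2 or compound 3 to compound 4 can be read, because all four compounds sit at the same limit: the limit of > 1000000 nM in this assay, at which 4 of the 4 values shown sit.

The compounds shown leave open whether any amine on the shared core gives a number in this assay, and how these amines would rank.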